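The source may report more compounds than this note shows. Statements on the series, on what has been measured and on what is new or still open speak of the compounds shown alone.

Measured compounds, cytotoxicity in a functional assay on MT4 cells (Homo sapiens); a lower number here means that less compound is tolerated, a higher number that more compound is tolerated:

compound 1 `COC(=O)CNC1=CS(=O)(=O)O[C@@]12[C@@H](CO[Si](C)(C)C(C)(C)C)O[C@@H](n1cc(C)c(=O)n(C)c1=O)[C@@H]2O[Si](C)(C)C(C)(C)C` — compound 1 gives 105000 nM
compound 2 `Cc1cn([C@@H]2O[C@H](CO[Si](C)(C)C(C)(C)C)[C@@]3(OS(=O)(=O)C=C3NCC(=O)C(=O)O)[C@H]2O[Si](C)(C)C(C)(C)C)c(=O)n(C)c1=O` — compound 2 gives 31100 nM

For the measured compounds named here, compound 1 holds the higher of the two numbers in this assay; the only neighbour is compound 2, reached by a change of carboxy in place of methoxy on a carbonyl carbon, which gives a 3.4-fold lower number from compound 1 to compound 2 (0.53 log units; beyond the scatter).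

Compound 3 `COC(=O)CCNC1=CS(=O)(=O)O[C@@]12[C@@H](CO[Si](C)(C)C(C)(C)C)O[C@@H](n1cc(C)c(=O)n(C)c1=O)[C@@H]2O[Si](C)(C)C(C)(C)C` differs from compound 1 by (methoxycarbonyl)methyl in place of methoxycarbonyl on a saturated chain carbon bound to an amine nitrogen. Going by the values given here, the single measured step concerns the carbonyl substituent and not the length of the chain between the amine nitrogen and the ester, so it does not bear on this change. Among the compounds with values here, no measured step speaks to lengthening the chain from (methoxycarbonyl)methyl to 2-(methoxycarbonyl)ethyl, and the ester itself is kept. The working expectation for this assay is therefore no step beyond the scatter, a 1.1-fold lower number from compound 1 to compound 3 (0.02 log units; within the scatter), in either direction. Compound 3 is estimated at 100000 nM, with a range from 40000 nM to 250000 nM.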

Compound 3, half-maximal cytotoxic concentration: > 250000 nM
Compound 3: only a limit was reported; the forecaster's own chance of this, stated with the estimate: 15%; at least 2.5-fold (0.39 log units) between middle value and limit.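

In this assay, compound 3 gives > 250000 nM, which is a limit and not a number. Lengthening (methoxycarbonyl)methyl to 2-(methoxycarbonyl)ethyl with the ester kept gives an at least 2.3-fold higher number from compound 1 to compound 3 (0.37 log units; beyond the scatter), so chain length at this place moves the read-out beyond the scatter, as the carbonyl substituent already did; against the carboxycarbonyl compound the gap is wider, an at least 8.0-fold higher number from compound 2 to compound 3 (0.90 log units; beyond the scatter). Both steps are minimum sizes only, because their upper end rests on a limit: the limit of > 250000 nM in this assay, at which 1 of the 3 values shown sits.

As far as these compounds go, the true size of the chain-length step therefore stays open. Also open, from the compounds shown here alone, is how a carboxylic acid in place of the ester on the longer chain, or a still longer chain, would read in this assay.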